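The compounds below may be only part of what the source reports. "The series", "measured", "known", "first", "only" and "open" are said of these compounds alone.

Among the measured compounds shown here, compound 2 `COc1ccc2c(c1)NC(=O)CN2c1nc(Nc2ccc(C#N)cc2)nc2ccccc12` gives the lower of the two numbers recorded in a functional assay on MCF7 cells (Homo sapiens) for inhibition, read by sulforhodamine B assay, with a stated time of 48 h; on this read-out lower numbers stand for stronger inhibition of growth and higher numbers for weaker inhibition of growth; the only neighbour is compound 1 `COc1ccc2c(c1)NC(=O)CN2c1nc(Nc2cccc(C#N)c2)nc2ccccc12`, which in this assay gives 384 nM, against 9.19 nM for compound 2. Compound 3 `COc1ccc2c(c1)NC(=O)CN2c1nc(COCCCC(=O)NO)nc2ccccc12` differs from compound 2 by (3-(hydroxycarbamoyl)propoxy)methyl in place of (4-cyanophenyl)amino on an aromatic carbon. For the measured compounds named here, the single measured step, a 42-fold lower number from compound 1 to compound 2 (1.62 log units; beyond the scatter), moved a nitrile around an aromatic ring and does not bear on removing that ring altogether, so no measured step speaks to this change. Compound 3 is therefore expected to give a markedly higher number, estimated at 300 nM with a range of 30 nM to 3000 nM, a step of a 33-fold higher number from compound 2 to compound 3 (1.51 log units; beyond the scatter).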

Compound 3, concentration for 50% growth inhibition: 1210 nM
Compound 3: middle estimate off by 4.0-fold (0.61 log units), on the low side, and the stated range covers the measured number.
By their numbers in this assay, from the lowest: compound 2; then compound 1; then compound 3.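

In this assay, putting (3-(hydroxycarbamoyl)propoxy)methyl, which has no ring, in place of (4-cyanophenyl)amino on this aromatic carbon gives a 130-fold higher number from compound 2 to compound 3 (2.12 log units; beyond the scatter), whereas the same replacement of (3-cyanophenyl)amino gives only a 3.2-fold higher number from compound 1 to compound 3 (0.50 log units; beyond the scatter). At this position, the chain thus gives a higher number than either cyanophenylamino group, and the size of the step depends on where the nitrile sat. Nothing available accounts for these steps. The compounds shown leave open how a longer chain, or a carboxylic acid in place of the hydroxycarbamoyl end, would read here. They also leave open whether a plain phenylamino group would stay near compound 2.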